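This account rests on a few compounds, and the source may have more. Where it says the series, first, only, none or still open, it means among the compounds named here.

In an ADME assay on Vero cells (Chlorocebus sabaeus) for cytotoxicity, read by resazurin assay, with a stated time of 3 days (on this read-out lower numbers stand for stronger inhibition and higher numbers for weaker inhibition), compound 1, `CN(C)c1cc2[nH]c(C3CCCCC3)nc2cc1NC(=O)c1ccc(Br)cc1`, gives > 100 ug/mL, which is a limit of the assay rather than a number. Compound 2, `CN(C)c1cc2[nH]c(C3CCCCC3)nc2cc1NC(=O)OCC(F)(F)F`, gives in this assay > 100 ug/mL, again only a limit. Compound 3, `CCCCCC(=O)Nc1cc2nc(C3CCCCC3)[nH]c2cc1N(C)C`, likewise reaches no more than the limit > 100 ug/mL in this assay. The three compounds share one core and differ only in the group on the carbonyl carbon, and because every one of them sits at the same boundary (the limit of > 100 ug/mL in this assay, at which 3 of the 3 values shown sit), none of the steps between them can be read: a step that the two limits leave unreadable from compound 1 to compound 2, a step that the two limits leave unreadable from compound 1 to compound 3 and a step that the two limits leave unreadable from compound 2 to compound 3 all remain without a size. Compound 4, `CN(C)c1cc2[nH]c(C3CCCCC3)nc2cc1NC(=O)c1ccc(F)cc1F`, differs from compound 3 by 2,4-difluorophenyl in place of pentyl on a carbonyl carbon. The nearest analogy, an aromatic ring in place of pentyl on the carbonyl carbon, is the reverse of a step that the two limits leave unreadable from compound 1 to compound 3, and that too is hidden by the limit. Compound 4 is therefore expected to show no step beyond the scatter, a step that the limit leaves unreadable from compound 3 to compound 4, and is estimated at 150 ug/mL, with a range from 60 ug/mL to 400 ug/mL, most likely reported again only as a limit.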

Compound 4, half-maximal inhibitory concentration: > 100 ug/mL
Compound 4 ended at the assay's limit; the forecaster's own chance of this, stated with the estimate: 85%; the middle value lies beyond the limit too.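

No step from compound 4 to compound 1, compound 2 or compound 3 can be read in this assay, and each of the four gives only a limit: the limit of > 100 ug/mL in this assay, at which 4 of the 4 values shown sit.

The compounds shown leave open whether the group on the carbonyl carbon affects this read-out at all.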